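The compounds below may be only part of what the source reports. "The series", "measured", "known", "first", "only" and "open" are said of these compounds alone.

Measured compounds in a physicochemical assay for lipophilicity, read by HPLC, measured as octanol-water partition, at pH 7.4; a higher number here means a more lipophilic compound, a lower number a more polar compound:
compound 1 `NC(=O)[C@@H](CCC(F)(F)F)N(CC1CCCC1)S(=O)(=O)c1ccc(Cl)cc1`: 5.15
compound 2 `NC(=O)[C@@H](CCC(F)(F)F)N(C[C@H]1CCCCO1)S(=O)(=O)c1ccc(Cl)cc1`: 4.3
compound 3 `NC(=O)[C@@H](CCC(F)(F)F)N(C[C@H]1CCCOC1)S(=O)(=O)c1ccc(Cl)cc1`: 3.6

Compound 3 stands lowest of the three; the steps of a number 1.55 log units lower from compound 1 to compound 3 (beyond the scatter) and a number 0.70 log units lower from compound 2 to compound 3 (beyond the scatter) both exceed the scatter, as does a number 0.85 log units lower from compound 1 to compound 2 (beyond the scatter). Compound 4 `NC(=O)[C@@H](CCC(F)(F)F)N(C[C@@H]1CCCOC1)S(=O)(=O)c1ccc(Cl)cc1` is not yet measured. It differs from compound 3 thus: the two compounds have the same atoms and bonds and differ only in configuration as drawn: 1 of 2 stereo elements differ; a stereocentre at a saturated ring carbon is drawn R in compound 3 and S in compound 4. Among the compounds with values here, none of the measured steps bears on this change directly; each of them swaps one ring for another, and none changes configuration alone. With the same atoms and bonds retained, the expected step is no change at the digits printed from compound 3 to compound 4 (within the scatter), not beyond the scatter. For compound 4 the estimate in this assay is 3.6, with a range from 3.3 to 3.9.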

Compound 4, distribution coefficient: 3.7
Compound 4: middle estimate off by 0.10 log units, on the low side, and the stated range covers the measured number.
By their numbers in this assay, from the lowest: compounds 3 and 4 (each within the scatter of the next); then compound 2; then compound 1.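

In this assay this position is now seen under a change of configuration alone, and a number 0.10 log units higher from compound 3 to compound 4 (within the scatter), with the only structural difference being this: the fact that compounds 3 and 4 differ only in the configuration as drawn. The gaps from the other rings hold for the second oxan-3-yl configuration too: a number 0.60 log units lower from compound 2 to compound 4 (beyond the scatter) and a number 1.45 log units lower from compound 1 to compound 4 (beyond the scatter). At this position, the ring swap therefore remains beyond the scatter with either configuration at the oxan-3-yl ring carbon.

Still open, as far as these compounds go, is whether reversing the configuration at the oxan-2-yl ring carbon would likewise stay within the scatter of compound 2. Also open, from the compounds shown here alone, is where an amine on this saturated chain carbon would fall in this assay.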